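The source may hold more compounds than are shown below. What is called first, only, known or untested is meant among the compounds shown, and "the series" means these compounds.

Compound 1 `CNc1nc(NC2(C#N)CCCCC2)nc(-n2cccn2)n1`; compound 2 `CNc1nc(NC2(C#N)CCCCC2)nc(N2CCCC2)n1`; compound 3 `CNc1nc(NC2(C#N)CCCCC2)nc(-n2cnc(C)n2)n1`, not yet measured.

In an in vitro assay on Sf21 cells for inhibition of high affinity 3',5'-cyclic-AMP phosphodiesterase 7A (Homo sapiens) (on this read-out lower numbers stand for stronger inhibition and higher numbers for weaker inhibition), compound 1 gives > 5000 nM, a limit rather than a number. In this assay compound 2 likewise gives > 5000 nM, also a limit. For the measured compounds named here, the single measured step, a step that the two limits leave unreadable from compound 1 to compound 2, cannot be read because of the limit of > 5000 nM in this assay, at which 2 of the 2 values shown sit. Compound 2 therefore stands only at the limit, with no number of its own. The change to compound 3 is 3-methyl-1H-1,2,4-triazol-1-yl in place of pyrrolidin-1-yl on an aromatic carbon. Going by the values given here, no measured step bears on this change. For compound 3 the expected step is a step that the limit leaves unreadable from compound 2 to compound 3, none beyond the scatter, most likely ending again at a limit. Compound 3 is estimated at 8000 nM, in the range 3000 nM to 30000 nM.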

Compound 3, half-maximal inhibitory concentration: > 5000 nM
Compound 3 ended at the assay's limit; the forecaster's own chance of this, stated with the estimate: 80%; the middle value lies beyond the limit too.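

No step among compound 1, compound 2 and compound 3 can be read in this assay, because each gives only a limit: the limit of > 5000 nM in this assay, at which 3 of the 3 values shown sit.

Which substituent on the shared core, if any, gives a readable value remains open.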